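Smaller Acyl Group on a Hydroxamic Acid Series

The source may report more compounds than this note shows. Statements on the series, on what has been measured and on what is new or still open speak of the compounds shown alone.

Compound 1 `COc1ccc(C(=O)N(O)C(C)c2ccc3oc(-c4ccccc4)cc3c2)cc1OC` is the weakest of the three compounds with numbers in hand: in an assay on RBL cells for inhibition of Polyunsaturated fatty acid 5-lipoxygenase (Rattus norvegicus) (a higher number here means a weaker inhibitor, a lower number a stronger inhibitor), compound 1 gives 200 nM. Compound 2 `COC(=O)CCCC(=O)N(O)C(C)c1ccc2oc(-c3cc(OC)c(OC)c(OC)c3)cc2c1` gives 40 nM in this assay, and compound 3 `CCCCc1cc2cc(C(C)N(O)C(=O)CCCC(=O)OC)ccc2o1` gives 50 nM; both differ from compound 1 in more than one place, so their gaps to it are read only as what the two numbers show, and in each case the gap is beyond the scatter. Compound 4 `COCC(=O)N(O)C(C)c1ccc2oc(-c3ccccc3)cc2c1` has not yet been measured. It differs from compound 1 by one change: methoxymethyl in place of 3,4-dimethoxyphenyl on a carbonyl carbon. For the measured compounds named here, no direct step between measured compounds covers this change. Both compound 2 and compound 3 carry a group other than 3,4-dimethoxyphenyl on the same carbonyl carbon, and compound 2 gives the lower number 40 nM, while compound 3 gives the lower number 50 nM; on that basis a modest move toward lower numbers seems plausible, though a result within the scatter of compound 1 cannot be ruled out. The expected step from compound 1 to compound 4 is a 1.7-fold lower number from compound 1 to compound 4 (0.22 log units; within the scatter). Compound 4 is therefore estimated at 120 nM, with a range from 40 nM to 400 nM.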

Compound 4, half-maximal inhibitory concentration: 160 nM
For compound 4 the middle estimate is 1.3-fold (0.12 log units) below the measured one; measured number inside the range.
By their numbers in this assay, from the lowest: compounds 2 and 3 (each within the scatter of the next); then compounds 4 and 1 (each within the scatter of the next).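

For the compounds shown here, on the carbonyl carbon whose other neighbour is the amide-type nitrogen, methoxymethyl in place of 3,4-dimethoxyphenyl gives a 1.3-fold lower number from compound 1 to compound 4 (0.10 log units; within the scatter) in this assay, the first direct step at this position, and it lies within the scatter. The six-membered aromatic ring and most of the 10 heavy atoms of the leaving group can therefore be exchanged for an open group of 3 heavy atoms, on the core of compound 1, without a difference beyond the scatter. Nothing available speaks to why these two groups read alike.

Going by these compounds, whether a carboxylic acid, an amine or a longer chain on this carbonyl carbon would read differently from methoxymethyl remains open. Also open, on these data alone, is what part, if any, the chain on the carbonyl carbon of compound 2 and compound 3 plays in their numbers, as each differs from compound 4 in more than one place.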